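The compounds below may be only part of what the source reports. "The series", "measured", "known", "first", "only" and "open" are said of these compounds alone.

Compound 1 `CCCS(=O)(=O)Nc1ccc(F)c(C(=O)Nc2cnc3[nH]nc(C)c3c2)c1F` gives 18300 ng.h/mL in an ADME assay on the whole organism (plasma, strain CD-1) for pharmacokinetics, with Mus musculus as the target, at a dose of 30 mg/kg by the oral route; on this read-out higher numbers stand for higher exposure at the dose given and lower numbers for lower exposure. Compound 2 `CCCS(=O)(=O)Nc1ccc(F)c(C(=O)Nc2cnc3[nH]nc(OC)c3c2)c1F` gives 190000 ng.h/mL in this assay.

Among the measured compounds shown here, on these two numbers compound 2 stands highest, and the only measured step is a 10-fold higher number from compound 1 to compound 2 (1.02 log units; beyond the scatter). Compound 3 `CCCS(=O)(=O)Nc1ccc(F)c(C(=O)Nc2cnc3[nH]nc(Br)c3c2)c1F` differs from compound 2 by bromo in place of methoxy on an aromatic carbon. For the measured compounds named here, no measured step covers this change; the single known step shows only that a change at this carbon can move the number a long way. The number for compound 3 in this assay is therefore expected to move downward by a 3.8-fold lower number from compound 2 to compound 3 (0.58 log units; beyond the scatter), with wide uncertainty. The estimate for compound 3 is 50000 ng.h/mL, within a range from 15000 ng.h/mL to 160000 ng.h/mL.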

Compound 3, area under the concentration-time curve in the Mus musculus assay: 52500 ng.h/mL
Beside the measured number, compound 3's estimate is 1.1-fold (0.02 log units) below it; measured number inside the range.
By their numbers in the Mus musculus assay, from the lowest: compound 1; then compound 3; then compound 2.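

In the Mus musculus assay a third group at this carbon again moves the number well beyond the scatter: a 3.6-fold lower number from compound 2 to compound 3 (0.56 log units; beyond the scatter), and a 2.9-fold higher number from compound 1 to compound 3 (0.46 log units; beyond the scatter), so the bromo group falls between methyl and methoxy. For the change from methoxy to bromo, exposure and solubility fall together, a link that rests on this single pair in a physicochemical assay for solubility, read by HPLC, in phosphate buffer, with a stated time of 24 h, at pH 6.5; on this read-out higher numbers stand for higher solubility and lower numbers for lower solubility: the measured solubility of compound 2, 4 ug/mL, and of compound 3, 1 ug/mL, a 4.0-fold lower number (0.60 log units; beyond the scatter) In the physicochemical assay compound 2 gives 4 ug/mL and compound 3 gives 1 ug/mL.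

Going by these compounds, it remains open how an amine or a longer chain such as ethoxy at this carbon would stand in the Mus musculus assay, and whether solubility and exposure keep moving together beyond this pair.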